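This account rests on a few compounds, and the source may have more. Where it says the series, first, only, none or still open, it means among the compounds named here.

In an ADME assay on cells (Hepatocyte, Mus musculus) for metabolic stability, with a stated time of 30 min (a lower number here means that less of the compound is left, a higher number that more of the compound is left), compound 1 (`CS(=O)(=O)NC1CCC(CN2CCN(c3cc(=O)c4cc(C(F)(F)F)cc([N+](=O)[O-])c4s3)CC2)CC1`) gives 111% and compound 2 (`CC(=O)NC1CCC(CN2CCN(c3cc(=O)c4cc(C(F)(F)F)cc([N+](=O)[O-])c4s3)CC2)CC1`) gives 94.9%, while compound 3 (`O=C(OC1CCC(CN2CCN(c3cc(=O)c4cc(C(F)(F)F)cc([N+](=O)[O-])c4s3)CC2)CC1)c1ccc(F)cc1`) gives only 1.5% and so stands lowest of the three. Compound 4 (`O=c1cc(N2CCN(CC3CCC(O)CC3)CC2)sc2c([N+](=O)[O-])cc(C(F)(F)F)cc12`) has not yet been measured. It differs from compound 3 by one change, hydrogen in place of (4-fluorophenyl)carbonyl on an oxygen on a saturated carbon, which turns ((4-fluorophenyl)carbonyl)oxy into hydroxy.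

Putting ((4-fluorophenyl)carbonyl)oxy on the saturated ring carbon gave two large steps (a number 109.5 percentage points lower from compound 1 to compound 3 (beyond the scatter)) and (a number 93.4 percentage points lower from compound 2 to compound 3 (beyond the scatter)). Exchanging methylsulfonyl for acetyl gave only a modest step (a number 16.1 percentage points lower from compound 1 to compound 2 (beyond the scatter)). Going by the values given here, no measured compound carries hydroxy, so the evidence is indirect, but removing the (4-fluorophenyl)carbonyl may undo much of the large fall seen for compound 3 (1.5%). A large rise is therefore expected in this assay, smaller than the full fall, as an estimated step (a number 73.5 percentage points higher from compound 3 to compound 4 (beyond the scatter)). Compound 4 is expected at 75% (estimated range 45% to 105%).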

Compound 4, percent of the compound remaining: 51.2%
The estimate for compound 4 lay 23.8 percentage points above the measured number; the measured number falls inside the stated range.
By their numbers in this assay, from the lowest: compound 3; then compound 4; then compound 2; then compound 1.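

In this assay, taking away the (4-fluorophenyl)carbonyl and leaving hydroxy gives a large recovery (a number 49.7 percentage points higher from compound 3 to compound 4 (beyond the scatter)), so the very low number of compound 3 depends on that group and not on the shared core alone. The recovery is only partial, though: hydroxy on the saturated ring carbon also stands apart from the two nitrogen-linked groups (a number 43.7 percentage points lower from compound 2 to compound 4 (beyond the scatter)) and (a number 59.8 percentage points lower from compound 1 to compound 4 (beyond the scatter)), which shows that a small group at this position does not by itself match acetamido or methanesulfonamido. Nothing measured here explains these differences.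

From the compounds shown here alone, whether a plain amine, a methoxy ether or a carboxylic acid on this ring carbon would stand nearer compound 4 or compound 1 remains open. The percentage remaining also does not show which part of any of these compounds is lost.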